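Chloro for Bromo: Estimating the Next Compound

The source may hold more compounds than are shown below. What is called first, only, known or untested is meant among the compounds shown, and "the series" means these compounds.

Measured so far in this cytotoxicity test:
Compound 1 `COc1ccc(C2=NN(C3=NC(=O)/C(=C4\C(=O)Nc5ccccc54)S3)C(c3ccc(OC)cc3)C2)cc1`: 100000 nM
Compound 2 `COc1ccc(C2=NN(C3=NC(=O)/C(=C4\C(=O)Nc5ccc(Br)cc54)S3)C(c3ccc(OC)cc3)C2)cc1`: 25300 nM

Two compounds have numbers in a functional assay on cells (Cancer cell lines, Homo sapiens) for cytotoxicity, read by sulforhodamine B assay, with a stated time of 48 h; a higher number here means a weaker inhibitor of growth, a lower number a stronger inhibitor of growth. Compound 1 gives 100000 nM, and compound 2 gives 25300 nM, the lowest of the two. Within the data shown here, the single known step between them is a 4.0-fold lower number from compound 1 to compound 2 (0.60 log units; beyond the scatter), where a bromo group entered in place of a hydrogen on an aromatic carbon.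

Compound 3 `COc1ccc(C2=NN(C3=NC(=O)/C(=C4\C(=O)Nc5ccc(Cl)cc54)S3)C(c3ccc(OC)cc3)C2)cc1` differs from compound 2 in one place: chloro in place of bromo on an aromatic carbon. Among the measured compounds shown here, no measured step exchanges one halogen for another, so the only step that bears on this change is the one from compound 1 to compound 2. That step shows that a halogen at this position gives a lower number than a hydrogen; chloro and bromo are both halogens, so the new change is expected to be smaller than that step, with the number rising slightly if at all. The expected size of the step from compound 2 to compound 3 is a 1.4-fold higher number from compound 2 to compound 3 (0.14 log units; within the scatter). Compound 3 is therefore estimated at 35000 nM, with a likely range from 12000 nM to 100000 nM.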

Compound 3, concentration for total growth inhibition: 430 nM
The estimate for compound 3 lay 81-fold (1.91 log units) above the measured number, outside the stated range (below it).
By their numbers in this assay, from the lowest: compound 3; then compound 2; then compound 1.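

In this assay the kind of halogen at this place on the ring matters far more than compound 1 and compound 2 could suggest: changing bromo to chloro brings a 59-fold lower number from compound 2 to compound 3 (1.77 log units; beyond the scatter) and dwarfs the earlier 4.0-fold lower number from compound 1 to compound 2 (0.60 log units; beyond the scatter) that came with bromo in place of hydrogen. Measured against hydrogen, chloro gives a 230-fold lower number from compound 1 to compound 3 (2.37 log units; beyond the scatter) and makes compound 3 the strongest inhibitor of growth of the three. At this position, then, two halogens cannot be treated as interchangeable, even though the change swaps only one heavy atom for another.

The compounds shown do not tell whether this large gain is particular to chloro or would also appear with fluoro, iodo, methyl or an amine at the same place on the ring. No measurement at hand accounts for the gap between chloro and bromo, so the size of this step remains an observation without an explanation.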